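Nitro to chloro on the sulfonyl aryl: lipophilicity notes

A few compounds are considered here, and "the series" means these few. Any claim that something is new, unique, unknown or untested is made for them only; others in the source may bear on it.

Measured compounds:
compound 1, `COc1ccc(C2C3CCCCC3=NN2S(=O)(=O)c2ccc([N+](=O)[O-])cc2)cc1`, 4.5
compound 2, `COc1ccc(C2C3CCCCC3=NN2S(=O)(=O)c2ccc(Cl)cc2)cc1`, 4.3
compound 3, `O=[N+]([O-])c1ccc(S(=O)(=O)N2N=C3CCCCC3C2c2ccc(F)cc2)cc1`, 4.9

In a physicochemical assay for lipophilicity, measured as octanol-water partition (a lower number here means a more polar compound, a higher number a more lipophilic compound), compound 1 gives 4.5. Compound 2 differs from compound 1 by chloro in place of nitro on an aromatic carbon, and the step of a number 0.20 log units lower from compound 1 to compound 2 (within the scatter). Compound 3 differs from compound 1 by fluoro in place of methoxy on an aromatic carbon; here the step of a number 0.40 log units higher from compound 1 to compound 3 (beyond the scatter), and in this assay compound 3 gives 4.9, the highest of the three numbers.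

Compound 4, `O=S(=O)(c1ccc(Cl)cc1)N1N=C2CCCCC2C1c1ccc(F)cc1`, has not yet been measured. It differs from compound 3 by chloro in place of nitro on an aromatic carbon. Among the measured compounds shown here, this is the same change, at the same kind of place, as the one made from compound 1 to compound 2, so the pair compound 3 and compound 4 is a second instance of it, on a core that differs from the core of compound 1 by fluoro in place of methoxy on an aromatic carbon. For the measured compounds named here, only one earlier instance is known, and the pair is too small to call a pattern.

The expectation for compound 4 rests on that single earlier step, because the step of a number 0.20 log units lower from compound 1 to compound 2 (within the scatter) was small and within the scatter. The step from compound 3 to compound 4 in this assay is therefore expected to be a number 0.20 log units lower from compound 3 to compound 4 (within the scatter). Compound 4 is estimated to give 4.7 in this assay, with a range from 4.3 to 5.1 expected to cover most repeat measurements.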

Compound 4, partition coefficient: 5.1
Beside the measured number, compound 4's estimate is 0.40 log units below it, within the range that was stated.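

In this assay the change of 4-nitrophenyl to 4-chlorophenyl has now been seen on two cores: the core of compound 1 gives a number 0.20 log units lower from compound 1 to compound 2 (within the scatter) and the fluoro core gives a number 0.20 log units higher from compound 3 to compound 4 (within the scatter), so on neither core does the change stand clear of repeat measurement, and the printed directions of the two steps carry no weight. The companion change, fluoro in place of methoxy, stands beyond the scatter with the chloro group in place, at a number 0.80 log units higher from compound 2 to compound 4 (beyond the scatter), as it does with the nitro group in place, at a number 0.40 log units higher from compound 1 to compound 3 (beyond the scatter), and neither of these two instances goes against the other. Two pairs show only that, in these four compounds, the nitro to chloro exchange left the number within the scatter on both cores; they do not establish a rule for other cores, and nothing available bears on the reason for the size of any of these steps.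

Still open, on these data alone, is how the same aromatic carbon behaves with a group of another kind, such as an amine or a carboxylic acid in place of nitro or chloro. Equally open, as far as these compounds go, is whether a longer chain, such as an ethoxy or butoxy group in place of methoxy or fluoro, would leave the nitro to chloro change within the scatter.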